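Second chloro added to compound 2

A few compounds are considered here, and "the series" means these few. Any claim that something is new, unique, unknown or untested is made for them only; others in the source may bear on it.

Compound 1 `Cc1cc(C(C)O)cc(C)c1/N=C/N(C)C` gives 40 mg/kg in a functional assay on the whole organism with Mus musculus as the target, in the writhing test; a higher number here means that more compound is needed for the effect, a lower number that less compound is needed. Compound 2 `Cc1cc(C(O)c2ccc(Cl)cc2)cc(C)c1/N=C/N(C)C` reaches only a limit of the assay, > 50 mg/kg in this assay. The step of an at least 1.2-fold higher number from compound 1 to compound 2 (0.09 log units; that floor lies within the scatter) is known only as a floor because compound 2 sits at the limit of > 50 mg/kg in this assay, at which 1 of the 2 values shown sits. Compound 3 `Cc1cc(C(O)c2ccc(Cl)c(Cl)c2)cc(C)c1/N=C/N(C)C` differs from compound 2 by chloro in place of hydrogen on an aromatic carbon. For the measured compounds named here, the single measured step, an at least 1.2-fold higher number from compound 1 to compound 2 (0.09 log units; that floor lies within the scatter), ends at the limit, so no movement beyond the scatter is expected in this assay. The expected step is a step that the limit leaves unreadable from compound 2 to compound 3. Compound 3 is estimated at 60 mg/kg, between 30 mg/kg and 120 mg/kg, most likely reported again only as a limit.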

Compound 3, dose for half-maximal effect: > 50 mg/kg
Compound 3: only a limit was reported; the forecaster's own chance of this, stated with the estimate: 65%; the middle value is on the limit's open side.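

No step from compound 2 to compound 3 can be read in this assay, because both are reported only as limits: the limit of > 50 mg/kg in this assay, at which 2 of the 3 values shown sit.

Going by these compounds, whether chloro in place of hydrogen on an aromatic carbon changes the dose needed stays open.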